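A 2,3-Dichlorophenyl Group Replaces 3-Methylphenyl

A few compounds are considered here, and "the series" means these few. Any claim that something is new, unique, unknown or untested is made for them only; others in the source may bear on it.

Within the data shown here, in a functional assay (muscle tissue) with Cavia porcellus as the target (a higher number here means that more compound is needed for the effect, a lower number that less compound is needed), compound 2 (`COC(=O)C1=C(C)N=C(C)/C(=C(\O)OC)C1c1cccc(C)c1`) gives 110 nM and stands highest of the two numbers so far, above compound 1 (`COC(=O)C1=C(C)N=C(C)/C(=C(\O)OC)C1c1ccccc1Br`) at 7.59 nM on the same read-out. Compound 3 (`COC(=O)C1=C(C)N=C(C)/C(=C(\O)OC)C1c1cccc(Cl)c1Cl`) keeps the shared core but carries 2,3-dichlorophenyl in place of 3-methylphenyl on a saturated ring carbon. Among the measured compounds shown here, one measured step bears on this change: a 14-fold higher number from compound 1 to compound 2 (1.16 log units; beyond the scatter), a large step beyond the scatter that exchanged 2-bromophenyl for 3-methylphenyl at the same place. The group in compound 3 again has a halogen at the position numbered 2, as in compound 1, so a large step back toward a lower number in this assay is expected, resting on this single comparison. An estimated 11-fold lower number from compound 2 to compound 3 (1.04 log units; beyond the scatter) is therefore expected. Compound 3 is expected at an estimated 10 nM, with 3 nM to 35 nM as its expected range.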

Compound 3, half-maximal effective concentration: 19.1 nM
Estimate against measurement, compound 3: 1.9-fold (0.28 log units) below; low and high end bracket the measured number.
By their numbers in this assay, from the lowest: compound 1; then compound 3; then compound 2.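

Replacing 3-methylphenyl with 2,3-dichlorophenyl gives a 5.8-fold lower number from compound 2 to compound 3 (0.76 log units; beyond the scatter) in this assay and so shows that a low number at this saturated ring carbon is not confined to 2-bromophenyl; among the three compounds, both halogen-bearing groups read lower than 3-methylphenyl, and none goes against this. The two halogen-bearing groups are still not interchangeable, since 2,3-dichlorophenyl in place of 2-bromophenyl gives a 2.5-fold higher number from compound 1 to compound 3 (0.40 log units; beyond the scatter) and this modest step lies beyond the scatter. No supporting evidence bears on these differences.

The compounds shown leave open how 2-chlorophenyl or 3-chlorophenyl would read, so the contribution of each chlorine in compound 3 cannot be separated. Also open, from the compounds shown here alone, is how a phenyl ring carrying an amine or a carboxylic acid would read at this place.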